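Shortening the chain on a pyridinone core

The source may report more compounds than this note shows. Statements on the series, on what has been measured and on what is new or still open speak of the compounds shown alone.

Compound 1 `COc1ccc(-c2ccn(CCC(C)C)c(=O)c2C#N)cc1`: 1150 nM
Compound 2 `CC(C)CCn1ccc(-c2ccc(Oc3ccncc3)cc2)c(C#N)c1=O`: 550 nM
Compound 3 `Cc1cc(Oc2ccc(-c3ccn(CCC(C)C)c(=O)c3C#N)cc2)ccn1`: 447 nM

Compound 3 has the lowest number of the three in a functional assay on CHO cells for positive allosteric modulation of metabotropic glutamate receptor 2 (Homo sapiens), read by scintillation counting and GTPgammaS binding, with a stated time of 30 min; on this read-out higher numbers stand for an effect only at larger amounts of compound and lower numbers for an effect already at smaller amounts. Its nearest neighbour is compound 2, which in this assay gives 550 nM, a gap that is a 1.2-fold lower number from compound 2 to compound 3 (0.09 log units; within the scatter) and so within the scatter; the two cannot be put in order. The step from the methyl ether of compound 1, which gives 1150 nM, is larger: a 2.6-fold lower number from compound 1 to compound 3 (0.41 log units; beyond the scatter), and the related change to compound 2 is a 2.1-fold lower number from compound 1 to compound 2 (0.32 log units; beyond the scatter).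

Compound 4 `CCCCn1ccc(-c2ccc(Oc3ccnc(C)c3)cc2)c(C#N)c1=O` keeps the whole aryl ether and nitrile part of compound 3 and differs only in the chain on the ring nitrogen: hydrogen in place of methyl on a saturated chain carbon bound to two saturated chain carbons. Neither measured step touches this chain; all three of them concern the oxygen-linked group, so there is no direct guide to how the chain shortening will read in this assay. For the measured compounds named here, with no measured counterpart, the expected step from compound 3 to compound 4 is put at a 1.3-fold higher number from compound 3 to compound 4 (0.13 log units; within the scatter), a change not expected to exceed the scatter. Compound 4 is therefore estimated to give 600 nM in this assay, with a range from 250 nM to 1500 nM.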

Compound 4, half-maximal effective concentration: 398 nM
The estimate for compound 4 lay 1.5-fold (0.18 log units) above the measured number; the range from low to high includes it.
By their numbers in this assay, from the lowest: compounds 4, 3 and 2 (each within the scatter of the next); then compound 1.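

Removing the methyl from the saturated chain carbon bound to two saturated chain carbons, which turns isopentyl into butyl, gives a 1.1-fold lower number from compound 3 to compound 4 (0.05 log units; within the scatter) in this assay, so compound 3 and compound 4 cannot be put in order. For the compounds shown here, the earlier steps all concerned the oxygen-linked group, and this pair is the first to read the chain itself: with the aryl ether and nitrile held fixed, the branching methyl of the isopentyl chain makes no difference beyond the scatter, and the straight butyl chain serves as well in this one case. No other measurement bears on this result, so nothing shown accounts for it.

This single pair leaves open whether the same shortening would read alike with the methyl ether of compound 1 or the pyridin-4-yl ether of compound 2, since the chain was compared only with the 2-methylpyridin-4-yl ether in place. It also leaves open how far the chain can vary, for instance whether a propyl or a longer hexyl chain, a cyclopropylmethyl group or a methoxyethyl chain would stay in the same range.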